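This account rests on a few compounds, and the source may have more. Where it says the series, first, only, none or still open, it means among the compounds named here.

Measured compounds:
Compound 1, `c1ccc(-c2nc[nH]n2)c(NCC2=NCCN2)c1`: 0.794 nM
Compound 2, `Cc1n[nH]c(-c2ccccc2NCC2=NCCN2)n1`: 794 nM
Compound 3, `Cn1nccc1-c1ccccc1NCC1=NCCN1`: 10 nM

In an in vitro functional assay on cells (Fibroblast) for agonist activity at Alpha-1A adrenergic receptor (Homo sapiens) (a higher number here means that more compound is needed for the effect, a lower number that less compound is needed), compound 3 holds the second highest of the three numbers: a 13-fold higher number from compound 1 to compound 3 (1.10 log units; beyond the scatter), and a 79-fold lower number from compound 2 to compound 3 (1.90 log units; beyond the scatter). Compound 4, `CC(C)n1nccc1-c1ccccc1NCC1=NCCN1`, differs from compound 3 by isopropyl in place of methyl on an aromatic nitrogen. None of the three measured steps changes a group on that ring nitrogen; each exchanges the five-membered ring itself, so they bear on this step only loosely. Among the measured compounds shown here, the one step in which a methyl entered a ring, a 1000-fold higher number from compound 1 to compound 2 (3.00 log units; beyond the scatter), was large, but at a different place. The chemist therefore expects a modest rise in the number for compound 4, a 4.0-fold higher number from compound 3 to compound 4 (0.60 log units; beyond the scatter), wide in its range. The estimate for compound 4 is 40 nM, expected between 10 nM and 160 nM.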

Compound 4, half-maximal effective concentration: < 100000 nM
Compound 4 was reported as a limit; the forecaster's own chance of this, stated with the estimate: 5%; the middle value lies beyond the limit too.
By their numbers in this assay, from the lowest: compound 1; then compound 3; then compound 2.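

In this assay compound 4 gives < 100000 nM, which is a limit and not a number. The step from compound 3 to compound 4 cannot be read from it. The compounds shown leave open how far isopropyl in place of methyl on an aromatic nitrogen moves the number.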